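A few compounds are considered here, and "the series" means these few. Any claim that something is new, unique, unknown or untested is made for them only; others in the source may bear on it.

Series notes. In an ADME assay on a cell-free system (plasma, Rattus norvegicus) for metabolic stability, read by LC-MS, with a stated time of 60 min, tested at 100 uM (on this read-out higher numbers stand for a more stable compound and lower numbers for a less stable compound), compound 1 `COc1cc(C(=O)O)ccc1OCCCCOc1ccc(C(=O)CC(C)(C)C)c(O)c1C` gives 48% and compound 2 `Cc1c(OCCCCOc2cccc(C(=O)O)c2)ccc(C(=O)CC(C)C)c1C` gives 106%. Compound 3 `Cc1c(OCCCCOCOc2ccc(C(=O)O)cc2)ccc(C(=O)CC2CCCC2)c1O` gives 100% in this assay, the second highest of the three numbers; it sits within the scatter of compound 2 and well beyond it from compound 1. Compound 4 `Cc1ccc(C(=O)O)cc1OCCCCOc1ccc(C(=O)CC2CCCC2)c(O)c1C` is the unmeasured analogue of compound 3; the change is 5-carboxy-2-methylphenyl in place of (4-carboxyphenoxy)methyl on an oxygen on a saturated carbon. For the measured compounds named here, no measured pair shows this change, so no step size is known. The expectation is a small downward step, likely within the scatter, taking the tight precedent of compound 3 at 100% with compound 1 at 48% as a lower warning. Compound 4 is therefore estimated at 88% (range 55% to 110%), an expected step of a number 12 percentage points lower from compound 3 to compound 4 (beyond the scatter).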

Compound 4, percent of the compound remaining: 100%
Estimate against measurement, compound 4: 12 percentage points below, and the stated range covers the measured number.
By their numbers in this assay, from the lowest: compound 1; then compounds 3, 4 and 2 (each within the scatter of the next).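

For the compounds shown here, the swap at this place, on an oxygen on a saturated carbon, gives no change at the digits printed from compound 3 to compound 4 (within the scatter) in this assay, the first step that can be read for a single change. Here 5-carboxy-2-methylphenyl serves as well as (4-carboxyphenoxy)methyl on this read-out, although the two groups differ in their heavy atoms and hydrogen-bond acceptors. Nothing available explains this flat step.

Going by these compounds alone, what sets the much lower number of compound 1, at 48%, remains open, since no single-change pair reaches it. Also open, going by these compounds, is whether a tetrazole in place of the carboxylic acid, or a longer chain carrying the aromatic ring, would hold the read-out.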